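This account rests on a few compounds, and the source may have more. Where it says the series, first, only, none or still open, it means among the compounds named here.

Measured compounds in a functional assay on CCRF-CEM cells (Homo sapiens), read by MTT assay, with a stated time of 72 h; on this read-out higher numbers stand for weaker inhibition and lower numbers for stronger inhibition:
compound 1 `COc1ncnc2c1c(-c1ccsc1)cn2[C@@H]1O[C@H](CO)[C@@H](O)[C@H]1O`, 2570 nM;
compound 2 `CN(C)c1ncnc2c1c(-c1ccsc1)cn2[C@@H]1O[C@H](CO)[C@@H](O)[C@H]1O`, 3480 nM;
compound 3 `CNc1ncnc2c1c(-c1ccsc1)cn2[C@@H]1O[C@H](CO)[C@@H](O)[C@H]1O`, reported only as a limit, > 20000 nM.

Compound 2 shows the highest of the two numbers in this assay; its nearest neighbour is compound 1, and the step of a 1.4-fold higher number from compound 1 to compound 2 (0.13 log units; within the scatter) lies within the scatter. Compound 3 sits at the limit of > 20000 nM in this assay, at which 1 of the 3 values shown sits. Compound 4 `CN(C)c1ncnc2c1c(-c1cc3ccccc3o1)cn2[C@@H]1O[C@H](CO)[C@@H](O)[C@H]1O` differs from compound 2 by 1-benzofuran-2-yl in place of thiophen-3-yl on an aromatic carbon. The measured steps of an at least 7.7-fold higher number from compound 1 to compound 3 (0.89 log units; beyond the scatter) and an at least 5.7-fold higher number from compound 2 to compound 3 (0.75 log units; beyond the scatter) concern the group on a different aromatic carbon, so neither bears on this change, and no direction can be drawn from them. In the absence of such guidance, the number for compound 4 is expected to stay near that of compound 2, giving an expected step of a 1.7-fold lower number from compound 2 to compound 4 (0.24 log units; within the scatter). The estimate for compound 4 is 2000 nM, with a wide range from 300 nM to 15000 nM.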

Compound 4, half-maximal inhibitory concentration: > 20000 nM
Compound 4: no number, only a limit; the forecaster's own chance of this, stated with the estimate: 15%; at least 10-fold (1.00 log units) between middle value and limit.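

In this assay compound 4 is reported only as a limit, > 20000 nM. The earlier steps shown here concerned a different aromatic carbon; here, at the place two ring bonds from the ring nitrogen, 1-benzofuran-2-yl in place of thiophen-3-yl gives an at least 5.7-fold higher number from compound 2 to compound 4 (0.75 log units; beyond the scatter), so this position does not tolerate every aromatic group. Compound 3 and compound 4 now both give no number: the limit of > 20000 nM in this assay, at which 2 of the 4 values shown sit.

The compounds shown leave open whether the added six-membered ring or the exchange of sulfur for oxygen matters here. A furan-2-yl or 1-benzothiophen-2-yl group at this place would separate the two.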